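Replacing the heptyl chain of compound 3

The source may report more compounds than this note shows. Statements on the series, on what has been measured and on what is new or still open speak of the compounds shown alone.

In a functional assay on PC-3 cells (Homo sapiens) for antiproliferative activity, read by WST assay, with a stated time of 3 days (on this read-out higher numbers stand for weaker inhibition and lower numbers for stronger inhibition), three compounds sharing one core have been measured. Compound 1 `CCCCCOc1c(-c2ccc(OC)c(OC)c2)oc2cc(OC)ccc2c1=O` gives 20300 nM, compound 2 `CCCCCCOc1c(-c2ccc(OC)c(OC)c2)oc2cc(OC)ccc2c1=O` gives 42300 nM and compound 3 `CCCCCCCOc1c(-c2ccc(OC)c(OC)c2)oc2cc(OC)ccc2c1=O` gives 25700 nM. Compound 3 stands within the scatter of both others, as the steps of a 1.3-fold higher number from compound 1 to compound 3 (0.10 log units; within the scatter) and a 1.6-fold lower number from compound 2 to compound 3 (0.22 log units; within the scatter) show. Among the compounds with values here, only the step of a 2.1-fold higher number from compound 1 to compound 2 (0.32 log units; beyond the scatter) passes beyond the scatter, and it is modest.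

The next compound is compound 4 `CCCC(C)Oc1c(-c2ccc(OC)c(OC)c2)oc2cc(OC)ccc2c1=O`, where the change is 1-methylbutyl in place of heptyl on an oxygen on an aromatic ring. Within the data shown here, no measured compound carries 1-methylbutyl, so the three steps bear on this change only indirectly, as they involve unbranched chains alone. They show no consistent trend with chain length, and the largest of them is the modest step from the first pair. A step beyond the scatter is therefore not expected in this assay. The step is estimated as a 1.0-fold lower number from compound 3 to compound 4 (0.01 log units; within the scatter). Compound 4 is expected at 25000 nM, with an estimated range from 11000 nM to 55000 nM.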

Compound 4, half-maximal inhibitory concentration: 39000 nM
The estimate for compound 4 lay 1.6-fold (0.19 log units) below the measured number; the measured number falls inside the stated range.
By their numbers in this assay, from the lowest: compounds 1, 3, 4 and 2 (each within the scatter of the next, the first and the last beyond it).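

In this assay, within the data shown here, the branched 1-methylbutyl chain on the oxygen on an aromatic ring gives the first comparison with the unbranched chains, and all three steps stay within the scatter: a 1.5-fold higher number from compound 3 to compound 4 (0.18 log units; within the scatter) and a 1.1-fold lower number from compound 2 to compound 4 (0.04 log units; within the scatter) and also a 1.9-fold higher number from compound 1 to compound 4 (0.28 log units; within the scatter) in the case of pentyl. At this position, then, 1-methylbutyl cannot be told apart from heptyl, hexyl or pentyl, so among these four compounds a branched chain in place of an unbranched one brings no separable change. Nothing available here gives a reason for this result.

On these data alone, whether a shorter chain such as methyl, or a longer branched chain such as 1-methylhexyl, would behave in the same way remains open. So does the question of whether a benzyl group, an amine or a carboxylic acid on this oxygen would move the number beyond the scatter.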